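From ethoxycarbonyl to carboxy at the assay limit

The compounds below may be only part of what the source reports. "The series", "measured", "known", "first", "only" and "open" are said of these compounds alone.

In a functional assay on Jurkat cells (Homo sapiens) for cytotoxicity, with a stated time of 72 h (a higher number here means that more compound is needed for the effect, a lower number that less compound is needed), compound 1 (`C=C[C@@](C)(/C=C/c1ccc(O)c(CO)c1)CCC=C(C)C`) gives > 49000 nM as a limit. Compound 2 (`C=C[C@@](C)(/C=C/c1ccc(O)c(C=O)c1)CCC=C(C)C`) gives > 49000 nM as a limit too. Compound 3 (`C=C[C@@](C)(/C=C/c1ccc(O)c(/C=C/C(=O)OCC)c1)CCC=C(C)C`) likewise gives > 49000 nM as a limit, so it has no number of its own and stands with the others at the limit of > 49000 nM in this assay, at which 3 of the 3 values shown sit, on this evidence. Compound 4 (`C=C[C@@](C)(/C=C/c1ccc(O)c(/C=C/C(=O)O)c1)CCC=C(C)C`) turns the ethoxycarbonyl of compound 3 into carboxy, with hydrogen in place of ethyl on an oxygen next to a carbonyl group. The nearest measured changes are a step that the two limits leave unreadable from compound 1 to compound 2 and a step that the two limits leave unreadable from compound 1 to compound 3 and a step that the two limits leave unreadable from compound 2 to compound 3 and all of them concern the same aromatic carbon, yet none has a readable size. No step size can be carried over from them, so no shift in either direction is expected. The expected step is a step that the limit leaves unreadable from compound 3 to compound 4 for now. In this assay compound 4 is estimated at 50000 nM within an expected range of 20000 nM to 100000 nM and will most likely be reported as a limit again.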

Compound 4, half-maximal effective concentration: > 49000 nM
Compound 4: a limit, no number; the forecaster's own chance of this, stated with the estimate: 85%; the middle value is on the limit's open side.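

In this assay, the steps to compound 4 from compound 1, compound 2 and compound 3 all run between limits and cannot be read, which leaves one shared result: the limit of > 49000 nM in this assay, at which 4 of the 4 values shown sit. The compounds shown leave open what concentration any of them needs for the effect, and whether any of these changes shifts it.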